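Adding trifluoromethyl to compound 1: an expected modest step

The compounds below may be only part of what the source reports. "The series", "measured", "known", "first", "only" and "open" are said of these compounds alone.

Among the compounds with values here, in a functional assay on HL-60 cells (Homo sapiens) for cytotoxicity, read by WST assay, with a stated time of 48 h (on this read-out lower numbers stand for an effect already at smaller amounts and higher numbers for an effect only at larger amounts of compound), compound 1 (`O=C1OC[C@H](Cc2ccccc2)[C@H]1Cc1ccccc1`) gives 77000 nM and holds the highest of the three numbers measured so far. Compound 2 (`O=C1OC[C@H](Cc2ccccc2)[C@H]1Cc1cccc(OC(F)(F)F)c1`) gives 34000 nM and compound 3 (`O=C1OC[C@H](Cc2ccccc2)[C@H]1Cc1cccc(C(F)(F)F)c1`) gives 34000 nM in the same test. Compound 4 (`O=C1OC[C@H](Cc2ccccc2)[C@H]1Cc1ccc(C(F)(F)F)cc1`) has not yet been measured. It differs from compound 1 by a single change (trifluoromethyl in place of hydrogen on an aromatic carbon): trifluoromethyl in place of hydrogen on an aromatic carbon, para to a large group.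

The closest measured precedent is a 2.3-fold lower number from compound 1 to compound 3 (0.36 log units; beyond the scatter) with the same group on a different aromatic carbon. Trifluoromethoxy in place of hydrogen gives a step of the same size (a 2.3-fold lower number from compound 1 to compound 2 (0.36 log units; beyond the scatter)), and the two substituted compounds do not separate (no change at the digits printed from compound 2 to compound 3 (within the scatter)). Within the data shown here, no measured compound carries a group in the place it takes in compound 4, so the transfer of these steps remains uncertain. A modest step towards a lower number is therefore expected, although a result within the scatter of compound 1 would not be surprising. The estimated step is a 2.1-fold lower number from compound 1 to compound 4 (0.33 log units; beyond the scatter) on this evidence. Compound 4 is expected at 36000 nM with an estimated range (from 16000 nM to 75000 nM).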

Compound 4, half-maximal effective concentration: 22000 nM
Compound 4: the middle estimate sits 1.6-fold (0.21 log units) above what was measured; measured number inside the range.
By their numbers in this assay, from the lowest: compounds 4, 2 and 3 (each within the scatter of the next); then compound 1.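

In this assay, within the data shown here, the trifluoromethyl group also acts on an aromatic carbon para to a large group, a place that no earlier compound had filled, and the result is (a 3.5-fold lower number from compound 1 to compound 4 (0.54 log units; beyond the scatter)). The change therefore gives a step beyond the scatter at a second place on this ring, so the effect seen with compound 3 is not confined to a single aromatic carbon. Compound 3 gives 34000 nM and compound 4 gives 22000 nM, numbers that lie within the scatter of each other, so these compounds do not show that either place on the ring is preferred for this group. Nothing available explains why the step has this size.

Going by these compounds, what remains open is whether this place responds to trifluoromethyl in particular or would respond equally to another group, such as a chlorine atom, a methoxy group, an amine or a carboxylic acid. The compounds shown also leave open whether the same group would give a comparable step on the other aromatic ring of the shared core, which stays unsubstituted throughout.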